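Carboxy to ethoxycarbonyl on compound 2

The source may report more compounds than this note shows. Statements on the series, on what has been measured and on what is new or still open speak of the compounds shown alone.

Compound 1 `Cc1nc(C)c(C(=O)Oc2ccccc2/C=C/C(=O)O)nc1C` gives 36700 nM in a functional assay on EA.hy 926 cells (Homo sapiens) for cytotoxicity, read by MTT assay, with stated times of 24 h and 12 h (a lower number here means that less compound is needed, a higher number that more compound is needed for the effect), and is the unsubstituted member of the three measured compounds. Compound 2 `COc1ccc(/C=C/C(=O)O)c(OC(=O)c2nc(C)c(C)nc2C)c1` gives 115000 nM in this assay while compound 3 `COc1cc(/C=C/C(=O)O)ccc1OC(=O)c1nc(C)c(C)nc1C` gives 69400 nM in the same test, and these two values lie within the scatter of each other. Among the measured compounds shown here, the only measured single-site step, a 3.1-fold higher number from compound 1 to compound 2 (0.50 log units; beyond the scatter) for methoxy in place of hydrogen on an aromatic carbon, lies beyond the scatter and is modest in size.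

Compound 4 `CCOC(=O)/C=C/c1ccc(OC)cc1OC(=O)c1nc(C)c(C)nc1C` differs from compound 2 by the change ethyl in place of hydrogen on an oxygen next to a carbonyl group with ethyl in place of hydrogen on an oxygen next to a carbonyl group, which reads as carboxy to ethoxycarbonyl. For the measured compounds named here, no measured pair carries this change, and the methoxy step concerns a different place, so it offers only a rough scale for one change and no direction. A step beyond the scatter is therefore not expected in this assay although the uncertainty is wide on both sides. The expected size is a 1.4-fold lower number from compound 2 to compound 4 (0.13 log units; within the scatter) and this remains an estimate until measured. For compound 4 the estimated value is 85000 nM with an expected range from 30000 nM to 220000 nM in this working note.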

Compound 4, half-maximal effective concentration: 138000 nM
The estimate for compound 4 lay 1.6-fold (0.21 log units) below the measured number; the range from low to high includes it.
By their numbers in this assay, from the lowest: compounds 1, 3, 2 and 4 (each within the scatter of the next, the first and the last beyond it).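

Carboxy to ethoxycarbonyl is the first change in the series at the carboxy end of the molecule, as compounds 1, 2 and 3 all carry the free carboxy group. In this assay the step of a 1.2-fold higher number from compound 2 to compound 4 (0.08 log units; within the scatter) stays within the scatter, unlike the methoxy step of a 3.1-fold higher number from compound 1 to compound 2 (0.50 log units; beyond the scatter) on the aromatic carbon, so on this background the free carboxy group and the ethoxycarbonyl group cannot be told apart and the hydrogen on this oxygen can be replaced by ethyl without a readable change in the number. No independent measurement is available to explain why the two compounds read alike.

On these data alone, this single pair rests on the methoxy pattern of compound 2, so it remains open whether ethoxycarbonyl reads the same way on the core of compound 1 or on the methoxy pattern of compound 3. Also open, as far as these compounds go, is how this position responds to a longer chain on the oxygen, such as butyl, or to a primary amide in place of the ethoxycarbonyl group.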